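The source may hold more compounds than are shown below. What is called first, only, known or untested is meant among the compounds shown, and "the series" means these compounds.

In an assay on isolated protein for inhibition of long-chain fatty acid transport protein 1 (Mus musculus) (on this read-out lower numbers stand for stronger inhibition and higher numbers for weaker inhibition), compound 1 `CCn1c(CNc2ccccc2)nnc1SCC(=O)Nc1ccccc1` does not give a number but only a limit of the method, > 10000 nM. Compound 1 thus stands at the limit of > 10000 nM in this assay, at which 1 of the 2 values shown sits. Going by the values given here, compound 2 `CCC(=O)c1ccc2oc(CS(=O)(=O)c3nnc(CNc4ccccc4)n3CC)nc2c1` shares part of its structure with compound 1 but differs in several places; in this assay compound 2 gives 11900 nM, so the two values together say only that both compounds are weak inhibitors. Compound 3 `CCn1c(CNc2ccccc2)nnc1SCC(=O)Nc1ccc(C(=O)NC)cc1` has not yet been tested. It differs from compound 1 in a single place: methylcarbamoyl in place of hydrogen on an aromatic carbon — in words, methylcarbamoyl in place of hydrogen on an aromatic carbon. Among the compounds with values here, no pair of measured compounds that differ in one place exists here, so no measured step shows what such a change does in this assay. With compound 1 already at the limit, the expectation for compound 3 is a small shift at most, in either direction, with nothing that can be called beyond the usual scatter. Compound 3 is therefore estimated at 9000 nM, with a likely range from 3000 nM to 30000 nM. That expected step reads an at least 1.1-fold lower number from compound 1 to compound 3 (0.04 log units; that floor lies within the scatter).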

Compound 3, half-maximal inhibitory concentration: > 10000 nM
Compound 3 ended at the assay's limit; the forecaster's own chance of this, stated with the estimate: 55%; middle value at least 1.1-fold (0.04 log units) from the limit.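

In this assay, going by these compounds alone, compound 3 gives only a limit of the method and no number, just as compound 1 does, so no step between compound 1 and compound 3 can be read: the limit of > 10000 nM in this assay, at which 2 of the 3 values shown sit. Whether methylcarbamoyl in place of hydrogen on an aromatic carbon changes inhibition at all, and in which direction, stays open with the compounds shown.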